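A few compounds are considered here, and "the series" means these few. Any claim that something is new, unique, unknown or untested is made for them only; others in the source may bear on it.

Compound 1 `COC(=O)C1=C(C)N=C(C)/C(=C(/O)OC)C1c1ccccc1OCCO[N+](=O)[O-]`: 38 nM
Compound 2 `COC(=O)C1=C(C)N=C(C)/C(=C(/O)OC)C1c1cccc(OCc2no[n+]([O-])c2C)c1`: 370 nM
Compound 3 `COC(=O)C1=C(C)N=C(C)/C(=C(/O)OC)C1c1cccc(OCc2nonc2C(N)=O)c1`: 2300 nM

All three share one core and were tested in an assay on Cortex for displacement of a labelled ligand from Voltage-dependent L-type calcium channel subunit alpha-1D (Rattus norvegicus); on this read-out higher numbers stand for weaker inhibition and lower numbers for stronger inhibition. Compound 1 holds the lowest number of the three, the nearest being compound 2 at 370 nM and the furthest compound 3 at 2300 nM. Compound 4 `COC(=O)C1=C(C)N=C(C)/C(=C(/O)OC)C1c1ccccc1OCc1c(C)no[n+]1[O-]` differs from compound 1 in one place: a group of 7 heavy atoms (3 carbon, 2 nitrogen, 2 oxygen; one five-membered aromatic ring with 3 hetero atoms) in place of a group of 5 heavy atoms (1 carbon, 1 nitrogen, 3 oxygen; no ring), on a saturated chain carbon bound to an oxygen on an aromatic ring. Going by the values given here, no measured pair makes this exact exchange. Among the compounds with values here, the one measured step, a 6.2-fold higher number from compound 2 to compound 3 (0.79 log units; beyond the scatter), swaps one five-membered ring for another and offers little guidance. Compound 2, which also carries a five-membered ring with 3 hetero atoms on a saturated chain carbon bound to an oxygen on an aromatic ring, is weaker than compound 1, so a modest rise is expected. For compound 4 the expected step is a 2.4-fold higher number from compound 1 to compound 4 (0.37 log units; beyond the scatter). Compound 4 is estimated at 90 nM, between 25 nM and 350 nM.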

Compound 4, inhibition constant: 32 nM
For compound 4 the middle estimate is 2.8-fold (0.45 log units) above the measured one, and the stated range covers the measured number.
By their numbers in this assay, from the lowest: compounds 4 and 1 (each within the scatter of the next); then compound 2; then compound 3.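

In this assay, going by these compounds alone, compound 4 carries a five-membered aromatic ring with 3 hetero atoms where compound 1 carries (nitrooxy)methyl, and the step, a 1.2-fold lower number from compound 1 to compound 4 (0.07 log units; within the scatter), is the first direct reading of this exchange. On a saturated chain carbon bound to an oxygen on an aromatic ring, this ring group and the ring-free (nitrooxy)methyl group therefore read alike. Nothing available explains this likeness. The compounds shown leave open how an amine or a carboxylic acid would read at this place. They also leave open what a longer chain would do there.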